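The source may hold more compounds than are shown below. What is called first, only, known or untested is meant among the compounds shown, and "the series" means these compounds.

Compound 3 `O=C(OCc1cccc(Oc2ccccc2)c1)c1cccc(S)n1` gives 75000 nM in an assay on isolated protein for inhibition of matrix metalloproteinase-9 (Homo sapiens); a lower number here means a stronger inhibitor, a higher number a weaker inhibitor; of the two numbers in hand it is the higher, and compound 1 `O=C(OCc1cccc(-c2ccccc2)c1)c1cccc(S)n1` sits nearest with 50000 nM, the step being a 1.5-fold higher number from compound 1 to compound 3 (0.18 log units; within the scatter). For compound 2 `O=C(OCc1cccc(C(F)(F)F)c1)c1cccc(=O)[nH]1` the outcome in this assay is > 150 nM, a limit of the assay rather than a number (the limit of > 150 nM in this assay, at which 1 of the 3 values shown sits). Compound 4 `O=C(OCc1cccc(C(F)(F)F)c1)c1cccc(S)n1` is not yet measured; it differs from compound 3 in that (trifluoromethyl in place of phenoxy on an aromatic carbon). For the measured compounds named here, the only measured step on the core shared by compound 1 and compound 3, a 1.5-fold higher number from compound 1 to compound 3 (0.18 log units; within the scatter), exchanged one aromatic substituent for another without leaving the scatter. Going by the values given here, no measured step on that core covers the trifluoromethyl, and compound 2 carries a different core and gives only a limit. The step of a 1.5-fold lower number from compound 3 to compound 4 (0.18 log units; within the scatter) is therefore expected to be small. Compound 4 is estimated at 50000 nM, range 12000 nM to 150000 nM.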

Compound 4, half-maximal inhibitory concentration: 126000 nM
Compound 4: middle estimate off by 2.5-fold (0.40 log units), on the low side; the range from low to high includes it.
By their numbers in this assay, from the lowest: compounds 1, 3 and 4 (each within the scatter of the next, the first and the last beyond it).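

Removing the ring altogether, with trifluoromethyl in place of phenoxy on the aromatic carbon, stays within the scatter in this assay: a 1.7-fold higher number from compound 3 to compound 4 (0.23 log units; within the scatter). Trifluoromethyl in place of phenyl gives the first step on the shared core beyond the scatter, though only a modest one: a 2.5-fold higher number from compound 1 to compound 4 (0.40 log units; beyond the scatter). Compound 2 gives a limit and not a number, so its step to compound 4 cannot be read: the limit of > 150 nM in this assay, at which 1 of the 4 values shown sits.

As far as these compounds go, whether an amine or a carboxylic acid on this aromatic carbon would shift the number remains open. So does how the core of compound 2 compares with the shared core at a readable value.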